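The compounds below may be only part of what the source reports. "The series", "measured", "known", "first", "only" and "open" are said of these compounds alone.

Measured so far in an ADME assay on the whole organism (Rattus norvegicus, strain Sprague-Dawley) for pharmacokinetics, using cassette dosing, at a dose of 0.5 mg/kg by the intravenous route; on this read-out higher numbers stand for fast clearance and lower numbers for slow clearance:
compound 1 `O=C(Nc1ccc2[nH]c(=O)oc2c1)C(=O)N1CCN(c2ccc(C(F)(F)F)cc2)CC1` gives 15.1 mL/min/kg
compound 2 `O=C(Nc1ccc2[nH]c(=O)oc2c1)C(=O)N1CCN(c2ccc(Cl)c(F)c2)CC1` gives 5.6 mL/min/kg

Compound 2 has the lower of the two numbers. Compound 3 `COc1ccc(N2CCN(C(=O)C(=O)Nc3ccc4[nH]c(=O)oc4c3)CC2)cc1F` has methoxy in place of chloro on an aromatic carbon, ortho to a fluoro group (methoxy in place of chloro on an aromatic carbon). Among the measured compounds shown here, only one measured step bears on this, a 2.7-fold lower number from compound 1 to compound 2 (0.43 log units; beyond the scatter), a modest change in the same aryl group. It does not show which way methoxy will go, but with compound 2 at 5.6 mL/min/kg as the lower number, a modest rise is expected. The estimated step is a 1.8-fold higher number from compound 2 to compound 3 (0.25 log units; within the scatter). The estimate for compound 3 is 10 mL/min/kg, with an expected range from 4.5 mL/min/kg to 24 mL/min/kg.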

Compound 3, clearance: 101 mL/min/kg
Beside the measured number, compound 3's estimate is 10-fold (1.00 log units) below it, outside the stated range (above it).
By their numbers in this assay, from the lowest: compound 2; then compound 1; then compound 3.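

In this assay this place on the aromatic ring proves highly sensitive: methoxy in place of chloro gives an 18-fold higher number from compound 2 to compound 3 (1.26 log units; beyond the scatter) in a swap of small groups. The 3-fluoro-4-methoxyphenyl group also differs from 4-(trifluoromethyl)phenyl, with a 6.7-fold higher number from compound 1 to compound 3 (0.83 log units; beyond the scatter) for that change, so neither earlier aryl group comes close to compound 3. No measurement available here accounts for this jump. Still open, on these data alone, is whether a hydroxyl group, an amine or a longer ether such as ethoxy at this place would track chloro or methoxy.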